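Lipophilicity notes: changing the group on the amide nitrogen

The source may report more compounds than this note shows. Statements on the series, on what has been measured and on what is new or still open speak of the compounds shown alone.

- compound 1 `COc1ccc(NC(=O)[C@H]2CCCN2C(=O)C2(c3cccc(Cl)c3)CCCC2)nc1` gives 6.8
- compound 2 `O=C1Cc2cc(NC(=O)[C@H]3CCCN3C(=O)C3(c4cccc(Cl)c4)CCCC3)ccc2N1` gives 5

In a physicochemical assay for lipophilicity, at pH 7.4 (a lower number here means a more polar compound, a higher number a more lipophilic compound), compound 2 is the lower of the two measured compounds. Compound 3 `CNC(=O)c1cccc(NC(=O)[C@H]2CCCN2C(=O)C2(c3cccc(Cl)c3)CCCC2)c1` is still unmeasured. It differs from compound 2 by a group of 10 heavy atoms (8 carbon, 1 nitrogen, 1 oxygen; one six-membered aromatic ring of carbon only) in place of a group of 10 heavy atoms (8 carbon, 1 nitrogen, 1 oxygen; one five-membered non-aromatic ring with 1 hetero atom, one six-membered aromatic ring of carbon only), on an amide-type nitrogen with 3-(methylcarbamoyl)phenyl entering on the amide-type nitrogen. Going by the values given here, only one measured step bears on this place: a number 1.80 log units lower from compound 1 to compound 2 (beyond the scatter) which is large. That step changed the heavy-atom count, whereas this change keeps it, so a much smaller shift is expected here. The expected step of no change at the digits printed from compound 2 to compound 3 (within the scatter) is none beyond the scatter. For compound 3 the estimated value is 5 within an expected range of 4.5 to 5.6.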

Compound 3, distribution coefficient: 5.5
The estimate for compound 3 lay 0.50 log units below the measured number, within the range that was stated.
By their numbers in this assay, from the lowest: compound 2; then compound 3; then compound 1.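

In this assay a change on the amide-type nitrogen that keeps the heavy-atom count and the hydrogen-bond donor and acceptor counts still gives a number 0.50 log units higher from compound 2 to compound 3 (beyond the scatter) and so those counts alone do not fix the value at this position. In place of 5-methoxypyridin-2-yl, 3-(methylcarbamoyl)phenyl gives a number 1.30 log units lower from compound 1 to compound 3 (beyond the scatter) and compound 1 remains the highest of the three. No measurement on hand accounts for either step.

Open, on these data alone, is where this assay would place an amine or a carboxylic acid in place of the methylcarbamoyl group, and whether a longer chain there would shift the number.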